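Carbonyl in place of a benzyl arm on the amine nitrogen

The source may report more compounds than this note shows. Statements on the series, on what has been measured and on what is new or still open speak of the compounds shown alone.

Of the compounds shown here, three have been measured in a functional assay on Bel-7402 cells (Homo sapiens) for antiproliferative activity, read by MTT assay, with a stated time of 72 h; on this read-out lower numbers stand for stronger inhibition and higher numbers for weaker inhibition. Compound 1 `COc1cccc(CNCc2c(C(=O)O)n(Cc3ccc(C)cc3)c3ccccc23)c1` gives 21500 nM in this assay. Compound 2 `COc1ccc(Cn2c(C(=O)O)c(CNCc3ccc(O)c(OC)c3)c3ccc(C(C)C)cc32)cc1` gives 8380 nM in this assay. For compound 3 `COc1ccc(Cn2c(C(=O)O)c(CNCc3cc(OC)ccc3O)c3ccc(C)cc32)cc1`, this assay reports > 50000 nM, which is a limit of the assay and not a number. Compound 3 thus stands at the limit of > 50000 nM in this assay, at which 1 of the 3 values shown sits, at the weak end of the values shown, with no number to place it more closely.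

Compound 4 `COc1ccc(Cn2c(C(=O)O)c(CNC(=O)c3cccc(OC)c3)c3ccc(C)cc32)cc1` has not yet been measured in this assay. It differs from compound 3 in one place: (3-methoxyphenyl)carbonyl in place of 2-hydroxy-5-methoxybenzyl on an amine nitrogen. The amine of compound 3 thereby becomes an amide in compound 4, and the hydroxy-bearing ring gives way to a ring carrying methoxy alone.

Going by the values given here, no step between measured compounds is available, so the size of the step to compound 4 can only be expected, not computed. Compound 1, whose amine nitrogen carries a methoxy-substituted benzyl arm rather than a carbonyl, gives 21500 nM in this assay, which suggests that a methoxyphenyl group on this nitrogen can go with a measurable number. The step of an at least 1.6-fold lower number from compound 3 to compound 4 (0.22 log units; that floor lies within the scatter) is therefore expected to run toward stronger inhibition, though the limit on compound 3 leaves its size uncertain. Compound 4 is estimated at 30000 nM in this assay, within 8000 nM to 60000 nM.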

Compound 4, half-maximal inhibitory concentration: > 50000 nM
Compound 4: only a limit was reported; the forecaster's own chance of this, stated with the estimate: 40%; middle value at least 1.6-fold (0.22 log units) from the limit.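

In this assay compound 4 gives > 50000 nM, which is a limit of the assay and not a number. Compound 3 also carries only a limit, so no step from compound 3 to compound 4 can be read: the limit of > 50000 nM in this assay, at which 2 of the 4 values shown sit.

On these data alone, whether (3-methoxyphenyl)carbonyl in place of 2-hydroxy-5-methoxybenzyl on this amine nitrogen changes inhibition at all stays open.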